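The source may hold more compounds than are shown below. What is called first, only, known or untested is meant among the compounds shown, and "the series" means these compounds.

Compounds in this set share one core, a pyrrolidine bearing a tert-butyl group and a difluorophenyl group, linked through an amide to an azole that carries a benzyl arm. Compound 1 `CC(C)(C)N1C[C@@H](C(=O)Nc2ncnn2Cc2ccccc2)[C@H](c2ccc(F)cc2F)C1` carries a plain benzyl arm on a triazole. In a functional assay for agonist activity at Melanocyte-stimulating hormone receptor (Homo sapiens), read by cAMP accumulation (on this read-out lower numbers stand for an effect already at smaller amounts and higher numbers for an effect only at larger amounts of compound), compound 1 reaches only the limit of the method, > 10000 nM, and no number is obtained; this is the case described by the limit of > 10000 nM in this assay, at which 1 of the 3 values shown sits. Compound 3 `CC(C)(C)N1C[C@@H](C(=O)Nc2nccn2Cc2cccc(Cl)c2)[C@H](c2ccc(F)cc2F)C1` places a chloro substituent on the benzyl ring and gives 1270 nM in this assay. Compound 2 `CC(C)(C)N1C[C@@H](C(=O)Nc2nccn2Cc2ccccc2N2CCC(CC(=O)O)CC2)[C@H](c2ccc(F)cc2F)C1` instead attaches a 4-(carboxymethyl)piperidin-1-yl group to the benzyl ring, and in this assay compound 2 gives 1980 nM. The numbers of compound 2 and compound 3 sit within the usual scatter of one another, so neither can be called the more potent of the two.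

Compound 4 `CC(C)(C)N1C[C@@H](C(=O)Nc2nccn2Cc2ccccc2N2CCC(C(=O)O)CC2)[C@H](c2ccc(F)cc2F)C1` differs from compound 2 in one place: carboxy in place of carboxymethyl on a saturated ring carbon. The acid is kept but the chain between it and the saturated ring is shortened. For the measured compounds named here, no measured pair here tests such a shortening. The expectation is that the step from compound 2 to compound 4 stays within the scatter, as a 1.0-fold higher number from compound 2 to compound 4 (0.00 log units; within the scatter) expresses. Compound 4 is therefore expected to give about 2000 nM in this assay, with a likely range from 800 nM to 5000 nM.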

Compound 4, half-maximal effective concentration: 460 nM
For compound 4 the middle estimate is 4.3-fold (0.64 log units) above the measured one; measured number outside the range, below it.
By their numbers in this assay, from the lowest: compound 4; then compounds 3 and 2 (each within the scatter of the next). At a limit, above all of these: compound 1.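

In this assay, the chain that holds the acid on the saturated ring turns out not to be a neutral detail: carboxy in place of carboxymethyl gives a 4.3-fold lower number from compound 2 to compound 4 (0.63 log units; beyond the scatter). The earlier compounds shown here could not show this, as no two of them differ in one place, whereas here the acid stays and only the chain between it and the ring changes, so a lower number means that compound 4 has its effect at smaller amounts than compound 2. Nothing measured in this set says why the shorter attachment gives the lower number.

Whether the acid itself is needed at this place stays open, as the compounds shown cannot tell how an amide or an amine on the same ring carbon would compare with carboxy. Also open, on these data alone, is how a longer chain, such as carboxyethyl, would read at this position, and whether the same change would give a similar step on a benzyl arm carrying a different ring.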